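Swapping a Piperidine for a Methoxyphenyl: Expected Solubility Loss

The source may report more compounds than this note shows. Statements on the series, on what has been measured and on what is new or still open speak of the compounds shown alone.

Compound 3 `Cc1noc(-c2nc(C)c3c(c2N)C(=O)N(CC2CCNCC2)C3=O)n1` gives 160000 nM in a physicochemical assay for solubility, using the shake flask method, in simulated intestinal fluid, measured as kinetic solubility, with a stated time of 2 h, at 25 degrees C, at pH 6.5 (on this read-out higher numbers stand for higher solubility and lower numbers for lower solubility), the highest of the two numbers shown; compound 1 `COC(=O)c1nc(C)c2c(c1N)C(=O)N(Cc1ccccc1)C2=O` gives 7400 nM, a lower number by a gap beyond the scatter. Compound 2 `CCCOC(=O)c1nc(C)c2c(c1N)C(=O)N(Cc1ccccc1)C2=O` reaches only the limit < 5000 nM. Among the measured compounds shown here, the one measured step, an at least 1.4-fold lower number from compound 1 to compound 2 (0.17 log units; that floor lies within the scatter), sits at a different place and does not bear on the present change. Compound 4 `COc1ccccc1CN1C(=O)c2c(C)nc(-c3nc(C)no3)c(N)c2C1=O` differs from compound 3 by 2-methoxyphenyl in place of piperidin-4-yl on a saturated chain carbon bound to an amide-type nitrogen in a ring, which makes compound 4 resemble compound 1 more closely than compound 3 does. On that resemblance the step of a 20-fold lower number from compound 3 to compound 4 (1.30 log units; beyond the scatter) is expected, well beyond the scatter. Compound 4 is therefore estimated at 8000 nM, within a range from 3000 nM to 25000 nM.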

Compound 4, solubility: < 5000 nM
Compound 4 was reported as a limit; the forecaster's own chance of this, stated with the estimate: 30%; middle value at least 1.6-fold (0.20 log units) away from the limit.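

In this assay, placing 2-methoxyphenyl in place of piperidin-4-yl on a saturated chain carbon bound to an amide-type nitrogen in a ring gives an at least 32-fold lower number from compound 3 to compound 4 (1.50 log units; beyond the scatter); this is the only measured step at this place among the compounds shown, and it is large. For compound 4, the reading < 5000 nM is a limit and not a number, so the full size of the step stays unknown: the limit of < 5000 nM in this assay, at which 2 of the 4 values shown sit.

The compounds shown do not separate the nitrogen of piperidin-4-yl from the rest of the change. A cyclohexyl group at this place, or a phenyl ring carrying an amine, would tell these apart.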